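The compounds below may be only part of what the source reports. "The series", "measured", "known", "first", "only" and "open" are said of these compounds alone.

Of the compounds shown here, two from this study have been tested in an ADME assay on MCF-10A cells (Homo sapiens) for cytotoxicity, read by sulforhodamine B assay, with a stated time of 48 h; a higher number here means a weaker inhibitor of growth, a lower number a stronger inhibitor of growth. Compound 1 `O=C1C(=O)N(CN2CCN(c3ccnc4cc(C(F)(F)F)ccc34)CC2)c2cc(Br)ccc21` gives 24500 nM in this assay. Compound 2 `NC(=S)N/N=C1/C(=O)N(CN2CCN(c3ccnc4cc(Cl)ccc34)CC2)c2cccc(Br)c21`, which carries a thiosemicarbazone in place of a second carbonyl and a chloro rather than a trifluoromethyl group, gives 29400 nM in this assay. The two numbers sit within the usual scatter of each other, so neither compound can be called the weaker or the stronger inhibitor of growth on this evidence; both are weak. Going by the values given here, no step between measured compounds that differ in one place exists here, so nothing measured shows how a single change shifts the read-out.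

Compound 3 `NC(=S)N/N=C1/C(=O)N(CN2CCN(c3ccnc4cc(Cl)ccc34)CC2)c2ccccc21` differs from compound 2 by hydrogen in place of bromo on an aromatic carbon. Among the compounds with values here, with no comparable step to lean on, the change from compound 2 to compound 3 is expected to produce no shift beyond the scatter in this assay. Compound 3 is therefore expected to give about 32000 nM in this assay, with a likely range from 11000 nM to 95000 nM. This estimate corresponds to an expected step of a 1.1-fold higher number from compound 2 to compound 3 (0.04 log units; within the scatter) that stays within the scatter.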

Compound 3, concentration for 50% growth inhibition: 27700 nM
Beside the measured number, compound 3's estimate is 1.2-fold (0.06 log units) above it, and the stated range covers the measured number.
By their numbers in this assay, from the lowest: compounds 1, 3 and 2 (each within the scatter of the next).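

Compound 2 and compound 3 form the first pair shown that differs in one place, so they give the first direct look at a single change in this assay. Hydrogen in place of bromo on an aromatic carbon of the six-membered aromatic ring of carbon only gives a 1.1-fold lower number from compound 2 to compound 3 (0.03 log units; within the scatter), so for this pair the two groups cannot be told apart in this read-out, and the bromo is not needed for the weak growth inhibition seen here. No outside measurement bearing on this result is available, so the finding stands as an observation about this one pair, with no explanation attached.

Still open, going by these compounds, is whether a different group on this same aromatic carbon, such as an amine, a carboxylic acid or a longer chain, would give a step beyond the scatter. Also open, on these data alone, is what the thiosemicarbazone and the chloro each contribute on their own, as compound 1 differs from compound 2 in more than one place and that pair cannot separate them.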